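A Ring Replaces a Chain on Compound 3

The source may hold more compounds than are shown below. What is called first, only, known or untested is meant among the compounds shown, and "the series" means these compounds.

Among the three measured compounds, compound 3 `CCCCNC(=O)Oc1ccc(C2=NCCO2)cc1` gives 34000 nM in an assay on cell membranes (strain Wistar) for inhibition of Monoglyceride lipase (Rattus norvegicus), read by HPLC (on this read-out higher numbers stand for weaker inhibition and lower numbers for stronger inhibition), the second highest number of the three. Compound 2 `O=C(NCc1ccccc1)Oc1ccc(C2=NCCS2)cc1` gives 42000 nM, which lies within the scatter of compound 3, while compound 1 `O=C(NC1CCCC1)Oc1ccc(C2=NCCS2)cc1` gives 11000 nM, a lower number beyond the scatter. Compound 4 `O=C(NC1CCCC1)Oc1ccc(C2=NCCO2)cc1` differs from compound 3 by cyclopentyl in place of butyl on an amide-type nitrogen. Among the measured compounds shown here, no measured pair makes exactly this exchange. The nearest guide is a 3.8-fold higher number from compound 1 to compound 2 (0.58 log units; beyond the scatter), where the cyclopentyl compound held the lower number. On that basis a modest drop in this assay is expected for compound 4, namely a 2.3-fold lower number from compound 3 to compound 4 (0.36 log units; beyond the scatter). The estimate for compound 4 in this assay is 15000 nM, expected to fall between 6000 nM and 40000 nM.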

Compound 4, half-maximal inhibitory concentration: 11000 nM
For compound 4 the middle estimate is 1.4-fold (0.13 log units) above the measured one, within the range that was stated.
By their numbers in this assay, from the lowest: compounds 1 and 4 (each within the scatter of the next); then compounds 3 and 2 (each within the scatter of the next).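

In this assay the change from butyl to cyclopentyl on the amide-type nitrogen, now read directly, gives a 3.1-fold lower number from compound 3 to compound 4 (0.49 log units; beyond the scatter) with the oxygen-holding five-membered ring kept in place. Keeping cyclopentyl and putting that ring where the sulfur-holding one stood gives no change at the digits printed from compound 1 to compound 4 (within the scatter) on this read-out. Cyclopentyl thus holds the lower number with either ring in the shared core.

Going by these compounds, how a cyclohexyl ring or a longer chain on that nitrogen would read stays open. Nothing at hand gives a reason for either step.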